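Repositioned hydroxyl on the side chain of compound 3

The source may report more compounds than this note shows. Statements on the series, on what has been measured and on what is new or still open speak of the compounds shown alone.

Measured so far:
compound 1, `COC1=C(OC)[C@H](O)[C@H](C/C=C(\C)CC/C=C(\C)C[C@H](O)/C=C(\C)CO)[C@@H](C)C1=O`, 12000 nM
compound 2, `COC1=C(OC)[C@H](O)[C@H](C/C=C(\C)CC/C=C(\C)CCC=C(C)C)[C@@H](C)C1=O`, 5700 nM
compound 3, `COC1=C(OC)[C@H](O)[C@H](C/C=C(\C)CC/C=C(\C)CC/C=C(\C)CO)[C@@H](C)C1=O`, 8200 nM

In a functional assay on A549 cells (Homo sapiens) for inhibition, read by sulforhodamine B assay, with a stated time of 48 h (on this read-out higher numbers stand for weaker inhibition of growth and lower numbers for stronger inhibition of growth), compound 3 gives the second highest of the three numbers; its nearest neighbour is compound 2, and both that gap and the gap to compound 1 lie within the scatter. Compound 4, `COC1=C(OC)[C@H](O)[C@H](C/C=C(\C)CC/C=C(\C)C[C@H](O)C=C(C)C)[C@@H](C)C1=O`, has not been measured. It differs from compound 3 by the counted difference (1-hydroxy-3-methylbut-2-en-1-yl in place of 3-(hydroxymethyl)but-2-en-1-yl on a saturated chain carbon bound to a double-bonded chain carbon).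

Within the data shown here, two measured steps bear on this change. The step of a 1.4-fold higher number from compound 2 to compound 3 (0.16 log units; within the scatter) shows what adding the 3-(hydroxymethyl)but-2-en-1-yl hydroxy does, and the step of a 1.5-fold lower number from compound 1 to compound 3 (0.17 log units; within the scatter) shows what removing the hydroxy on the saturated chain carbon does; the combined step a 2.1-fold lower number from compound 1 to compound 2 (0.32 log units; beyond the scatter) is modest. Compound 4 holds the second of these hydroxy groups but not the first, so the two small effects are expected to cancel.

Compound 4 is therefore estimated at 8500 nM, range 4000 nM to 18000 nM, a step of a 1.0-fold higher number from compound 3 to compound 4 (0.02 log units; within the scatter) expected to stay within the scatter.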

Compound 4, concentration for 50% growth inhibition: 9600 nM
Estimate against measurement, compound 4: 1.1-fold (0.05 log units) below; measured number inside the range.
By their numbers in this assay, from the lowest: compounds 2, 3, 4 and 1 (each within the scatter of the next, the first and the last beyond it).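

In this assay, shifting the hydroxy so that 1-hydroxy-3-methylbut-2-en-1-yl replaces 3-(hydroxymethyl)but-2-en-1-yl gives a 1.2-fold higher number from compound 3 to compound 4 (0.07 log units; within the scatter), so with the same atoms joined differently, this change stays within the scatter. Placing a hydroxy on the saturated chain carbon bound to a double-bonded chain carbon and a saturated chain carbon gives a 1.7-fold higher number from compound 2 to compound 4 (0.23 log units; within the scatter), while removing the other hydroxy gives a 1.3-fold lower number from compound 1 to compound 4 (0.10 log units; within the scatter), and the first of these hydroxy groups now reads alike on two cores: the same change on two cores in this assay, a 1.5-fold lower number (0.17 log units; within the scatter) from compound 1 to compound 3 and a 1.7-fold lower number (0.23 log units; within the scatter) from compound 4 to compound 2, 1.2-fold (0.06 log units) apart, within the scatter of two such steps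
The other hydroxy also reads alike on two cores: the same change on two cores in this assay, a 1.4-fold higher number (0.16 log units; within the scatter) from compound 2 to compound 3 and a 1.3-fold higher number (0.10 log units; within the scatter) from compound 4 to compound 1, 1.2-fold (0.06 log units) apart, within the scatter of two such steps

The compounds shown leave open whether an amine or a carboxylic acid in place of either hydroxy would give a step beyond the scatter. On these data alone, the effect of the opposite configuration at the hydroxy-bearing stereocentre also remains open.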